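Taking the methyl off an aromatic nitrogen of compound 1

The source may report more compounds than this note shows. Statements on the series, on what has been measured and on what is new or still open speak of the compounds shown alone.

Compound 1 `COc1ccc(N(C)c2nc(C)nc3c2nc(C)n3C)cc1`: 8700 nM
Compound 2 `Cc1ccc(N(C)c2nc(C)nc3c2nc(C)n3C)cc1`: > 100000 nM
Compound 3 `COc1ccc(N(C)c2nc(C)nc3c2ncn3C)cc1`: 15000 nM

Among the measured compounds shown here, in a functional assay (Mus musculus) for inhibition, read by cell counting, with a stated time of 3 days (on this read-out lower numbers stand for stronger inhibition and higher numbers for weaker inhibition), compound 1 gives 8700 nM, one of only two true numbers, and the other lies close: a 1.7-fold higher number from compound 1 to compound 3 (0.24 log units; within the scatter). Compound 2 reads > 100000 nM, which is a limit of the assay and not a number.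

Compound 4 `COc1ccc(N(C)c2nc(C)nc3[nH]c(C)nc23)cc1` has not been measured yet. Its difference from compound 1 is hydrogen in place of methyl on an aromatic nitrogen. In words, this is hydrogen in place of methyl on an aromatic nitrogen.

For the measured compounds named here, no measured step touches that nitrogen, so the evidence is indirect. The nearest parallel is the same swap of methyl for hydrogen made on an aromatic carbon, which gave only a 1.7-fold higher number from compound 1 to compound 3 (0.24 log units; within the scatter). Methyl in place of methoxy on an aromatic carbon gave an at least 11-fold higher number from compound 1 to compound 2 (1.06 log units; beyond the scatter), a large step, but it concerns a different group and says little about this change.

A modest move toward weaker inhibition therefore seems the likeliest outcome, with real uncertainty about its size. The expected step in this assay is a 2.3-fold higher number from compound 1 to compound 4 (0.36 log units; beyond the scatter). For compound 4 the estimate is 20000 nM, with an expected range from 5000 nM to 70000 nM.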

Compound 4, half-maximal inhibitory concentration: 8900 nM
Beside the measured number, compound 4's estimate is 2.2-fold (0.35 log units) above it; the measured number falls inside the stated range.
By their numbers in this assay, from the lowest: compounds 1, 4 and 3 (each within the scatter of the next). At a limit, above all of these: compound 2.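

In this assay, the methyl on this aromatic nitrogen of the five-membered aromatic ring can give way to hydrogen with no difference that the measurement can resolve: the change is a 1.0-fold higher number from compound 1 to compound 4 (0.01 log units; within the scatter). Among the compounds shown here, no earlier compound altered this nitrogen, so this is the first direct sign that the methyl here is not needed for the inhibition seen in this cell-counting read-out, and that a free ring nitrogen bearing hydrogen is compatible with it. It also matches the other swap of methyl for hydrogen, this one on an aromatic carbon, which is a 1.7-fold higher number from compound 1 to compound 3 (0.24 log units; within the scatter), so neither of these two methyl groups has a measurable part in the value of compound 1.

The compounds shown hold no measurement that explains why this nitrogen accepts the change so readily. They also leave open how much room there is at this nitrogen, since only hydrogen and methyl appear there, and an ethyl group, a longer chain or a chain ending in an amine or a carboxylic acid could give a very different answer.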